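Extending the Anilide Aryl Group with a Cyanophenyl

A few compounds are considered here, and "the series" means these few. Any claim that something is new, unique, unknown or untested is made for them only; others in the source may bear on it.

In a functional assay on SK-OV-3 cells (Homo sapiens) for antiproliferative activity, read by MTT assay, with a stated time of 72 h (on this read-out lower numbers stand for stronger inhibition and higher numbers for weaker inhibition), three compounds sharing one core have been tested. Compound 1, `O=C(CCc1cccc2c1B(O)OC2)Nc1nccs1`, gives only a limit, > 100000 nM, and not a number. Compound 2, `O=C(CCc1cccc2c1B(O)OC2)Nc1ccc(F)cc1`, gives 720 nM, and compound 3, `O=C(CCc1cccc2c1B(O)OC2)Nc1cccc(I)c1`, gives 630 nM. Compound 3 holds the lower of the two numbers, but the step of a 1.1-fold lower number from compound 2 to compound 3 (0.06 log units; within the scatter) is within the scatter, so compounds 2 and 3 cannot be ranked. Both steps away from compound 1 were large: an at least 130-fold lower number from compound 1 to compound 2 (2.14 log units; beyond the scatter) and an at least 150-fold lower number from compound 1 to compound 3 (2.20 log units; beyond the scatter).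

Compound 4, `N#Cc1cccc(-c2cccc(NC(=O)CCc3cccc4c3B(O)OC4)c2)c1`, is not yet measured. It differs from compound 3 in one place: 3-cyanophenyl in place of iodo on an aromatic carbon. Among the compounds with values here, no measured step tests this exact change. The nearest guide is the swap of 4-fluorophenyl for 3-iodophenyl on the amide-type nitrogen, which moved the number little, whereas exchanging the whole ring on that nitrogen moved it greatly. Changing only a substituent on the retained ring suggests a small step in this assay, in either direction. Compound 4 is therefore expected at 500 nM, between 150 nM and 2000 nM, a step of a 1.3-fold lower number from compound 3 to compound 4 (0.10 log units; within the scatter) that may not exceed the scatter.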

Compound 4, half-maximal inhibitory concentration: 120 nM
Estimate against measurement, compound 4: 4.2-fold (0.62 log units) above; the whole stated range lies above it.
By their numbers in this assay, from the lowest: compound 4; then compounds 3 and 2 (each within the scatter of the next). At a limit, above all of these: compound 1.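

Compounds 2 and 3 could not be ranked, so the earlier data gave no sign that changing a substituent on the retained ring could shift the result in this assay. Compound 4 supplies that sign: 3-cyanophenyl in place of iodo on an aromatic carbon gives a 5.3-fold lower number from compound 3 to compound 4 (0.72 log units; beyond the scatter), so this position tolerates a whole second aromatic ring, and the outcome there is not limited to small differences. Nothing among the measurements shown explains why the number falls with this change.

As far as these compounds go, what remains open is whether the added ring alone accounts for the step or whether its nitrile takes part. A plain phenyl ring at this position, or a phenyl ring bearing a carboxylic acid or an amine in place of the nitrile, would help to separate the two.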